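The source may report more compounds than this note shows. Statements on the series, on what has been measured and on what is new or still open speak of the compounds shown alone.

Compound 3 `CS(=O)(=O)Nc1ccccc1-c1ccc(COC2CC[C@H](N3CCCCCC3)[C@H]2OC/C=C\CCC(=O)O)cc1` gives 10 nM in a functional assay on blood for antagonist activity at thromboxane A2 receptor (Homo sapiens) (a higher number here means weaker binding, a lower number tighter binding), the second highest of the three numbers measured; its nearest neighbour is compound 2 `O=C(O)CC/C=C\CO[C@H]1C(OCc2ccc(-c3ccccc3O)cc2)CC[C@@H]1N1CCCCCC1` at 15.9 nM, with a 1.6-fold lower number from compound 2 to compound 3 (0.20 log units; within the scatter), and its furthest is compound 1 `O=C(O)CC/C=C\CO[C@H]1C(OCc2ccc(-c3ccccc3CCO)cc2)CC[C@@H]1N1CCCCCC1` at 2 nM, with a 5.0-fold higher number from compound 1 to compound 3 (0.70 log units; beyond the scatter). Compound 4 `NC(=O)c1ccccc1-c1ccc(COC2CC[C@H](N3CCCCCC3)[C@H]2OC/C=C\CCC(=O)O)cc1` differs from compound 3 in one place: carbamoyl in place of methanesulfonamido on an aromatic carbon. Among the measured compounds shown here, the steps that bear on this position are an 8.0-fold higher number from compound 1 to compound 2 (0.90 log units; beyond the scatter) and a 5.0-fold higher number from compound 1 to compound 3 (0.70 log units; beyond the scatter), both modest, while the exchange of hydroxy for methanesulfonamido at the same carbon stayed within the scatter. A small group of similar kind at this position is therefore expected to give a step of about a 1.2-fold higher number from compound 3 to compound 4 (0.08 log units; within the scatter), not clearly beyond the scatter. Compound 4 is estimated at 12 nM in this assay, within a range from 4 nM to 35 nM.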

Compound 4, dissociation constant: 15.9 nM
Compound 4: middle estimate off by 1.3-fold (0.12 log units), on the low side, and the stated range covers the measured number.
By their numbers in this assay, from the lowest: compound 1; then compounds 3, 2 and 4 (each within the scatter of the next).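

In this assay carbamoyl at this aromatic carbon gives a 1.6-fold higher number from compound 3 to compound 4 (0.20 log units; within the scatter) against methanesulfonamido and no change at the digits printed from compound 2 to compound 4 (within the scatter) against hydroxy, so these three groups cannot be told apart. Only 2-hydroxyethyl stands apart, now against a third replacement, with an 8.0-fold higher number from compound 1 to compound 4 (0.90 log units; beyond the scatter) as the step to carbamoyl. No accompanying data account for this gap. On these data alone, whether the gap depends on the chain of 2-hydroxyethyl or on its terminal hydroxy remains open. Ethyl, 2-aminoethyl and 3-hydroxypropyl at this carbon would test that.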